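The source may hold more compounds than are shown below. What is called first, only, known or untested is meant among the compounds shown, and "the series" means these compounds.

Of the compounds shown here, three have so far been measured in a functional assay on C6 cells (Rattus norvegicus) for cytotoxicity, read by MTT assay, with a stated time of 24 h, tested at 12 ug/mL; on this read-out lower numbers stand for a stronger effect and higher numbers for a weaker effect at the one concentration tested. Compound 3 `O=C(CSc1nnnn1-c1ccccc1)N/N=c1/scc(-c2ccccc2)n1-c1ccccc1` gives 47.1%, the lowest of the three numbers and thus the strongest effect seen to date. Compound 1 `Cc1ccc(-c2cs/c(=N/NC(=O)CSc3nnnn3C)n2-c2ccccc2)cc1` gives 68.8%, and compound 2 `Cn1cnnc1SCC(=O)N/N=c1/scc(-c2ccccc2)n1-c1ccccc1` gives 79.6%; the gaps from compound 3 to each of them lie beyond the scatter. Compound 4 `Cn1nnnc1SCC(=O)N/N=c1/scc(-c2ccccc2)n1-c1ccccc1` has not yet been measured. It differs from compound 3 in one place: methyl in place of phenyl on an aromatic nitrogen. Within the data shown here, only one measured step touches this group, a number 32.5 percentage points lower from compound 2 to compound 3 (beyond the scatter), and that step altered the ring as well as the group on it, so it bears on the present change only in part. Compound 1, which carries the same 1-methyl-1H-tetrazol-5-yl group as compound 4 but differs elsewhere, stands clearly above compound 3. Weighing both, compound 4 is expected to shift toward a weaker effect, by a number 17.9 percentage points higher from compound 3 to compound 4 (beyond the scatter). The estimate for compound 4 in this assay is 65%, in the range 45% to 85%.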

Compound 4, a percentage reported as activity, at one concentration (the size of the read-out at that concentration, not a potency): 80.7%
The estimate for compound 4 lay 15.7 percentage points below the measured number; low and high end bracket the measured number.
By their numbers in this assay, from the lowest: compound 3; then compound 1; then compounds 2 and 4 (each within the scatter of the next).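

In this assay, the phenyl itself is what separates the two tetrazole compounds: methyl in its place gives a number 33.6 percentage points higher from compound 3 to compound 4 (beyond the scatter), so the tetrazole ring alone does not carry the lower number of compound 3. The ring swap with methyl kept on the ring gives a number 1.1 percentage points higher from compound 2 to compound 4 (within the scatter), so this pair shows no difference between 1-methyl-1H-tetrazol-5-yl and 4-methyl-4H-1,2,4-triazol-3-yl. Elsewhere on the core, hydrogen in place of methyl on an aromatic carbon gives a number 11.9 percentage points higher from compound 1 to compound 4 (beyond the scatter), so that methyl also counts, though nothing available explains any of these shifts.

The compounds shown leave open whether a benzyl group or a cyclohexyl ring on the tetrazole nitrogen would keep the lower number of compound 3. They also leave open whether adding that aromatic methyl to compound 3 would lower its number further.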